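Methoxy in place of chloro: the step to compound 4

This account rests on a few compounds, and the source may have more. Where it says the series, first, only, none or still open, it means among the compounds named here.

Values in a functional assay on HT-29 cells (Homo sapiens) for antiproliferative activity, read by MTT assay, with a stated time of 24 h (a lower number here means a stronger inhibitor, a higher number a weaker inhibitor), are these.
Compound 1 (`COc1ccc(/C=C/C(=O)c2ccc(OC)c3c2OC(C)(C)C=C3)c(F)c1`) gives > 10000 nM (a limit)
Compound 2 (`COc1ccc(C(=O)/C=C/c2ccc(Br)cc2)c2c1C=CC(C)(C)O2`) gives > 10000 nM (a limit)
Compound 3 (`COc1ccc(C(=O)/C=C/c2ccccc2Cl)c2c1C=CC(C)(C)O2`) gives > 10000 nM (a limit)

Compound 3 stands at > 10000 nM which is a limit. The whole set sits at the limit of > 10000 nM in this assay, at which 3 of the 3 values shown sit, and offers no number to rank against.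

Compound 4 (`COc1ccccc1/C=C/C(=O)c1ccc(OC)c2c1OC(C)(C)C=C2`) has methoxy in place of chloro on an aromatic carbon, ortho to a large group. Three measured steps change this same phenyl group (a step that the two limits leave unreadable from compound 1 to compound 2; a step that the two limits leave unreadable from compound 1 to compound 3; a step that the two limits leave unreadable from compound 2 to compound 3). None has a readable size, so they support no expected direction.

In this assay the expected result is a number no higher from compound 3 to compound 4 (the limit leaves the size open) with no firm direction. Compound 4 is estimated at 10000 nM within a range from 3000 nM to 30000 nM and may again return only a limit.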

Compound 4, half-maximal inhibitory concentration: > 10000 nM
Compound 4 gave a limit, no number; the forecaster's own chance of this, stated with the estimate: 65%; the middle value sits exactly at the limit.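

Compound 4 returned only a limit, so no new step can be read from it to compound 1, compound 2 or compound 3: the limit of > 10000 nM in this assay, at which 4 of the 4 values shown sit. Which of these phenyl groups, if any, gives the stronger inhibitor stays open.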